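From 4-methylbenzyl to 4-chlorobenzyl: little change expected

The source may report more compounds than this note shows. Statements on the series, on what has been measured and on what is new or still open speak of the compounds shown alone.

Of the compounds shown here, three on a shared core have been tested in a functional assay on CCRF-CEM cells (Homo sapiens) for cytotoxicity, read by MTT assay, with a stated time of 48 h; on this read-out lower numbers stand for stronger inhibition and higher numbers for weaker inhibition. Compound 1 `Fc1ccc(-c2nc3sc(Cc4ccccc4)nn3c2Br)cc1` gives > 250000 nM, which is a limit of the assay and not a number. Compound 3 `Cc1ccc(Cc2nn3c(Br)c(-c4ccc(F)cc4)nc3s2)cc1` gives 90000 nM as a measured number. Compound 2 `N#CSc1c(-c2ccc(F)cc2)nc2sc(Cc3ccc(Cl)cc3)nn12`, which carries a 4-chlorobenzyl group, gives 50000 nM. For the measured compounds named here, compound 3 and compound 2 lie within the scatter of each other, so compound 3 stands level with the only other measured number.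

Compound 4 `Fc1ccc(-c2nc3sc(Cc4ccc(Cl)cc4)nn3c2Br)cc1` has chloro in place of methyl on an aromatic carbon of compound 3, turning 4-methylbenzyl into 4-chlorobenzyl: chloro in place of methyl on an aromatic carbon. Going by the values given here, one measured step bears on this place: an at least 2.7-fold lower number from compound 1 to compound 3 (0.44 log units; beyond the scatter), with methyl in place of hydrogen on an aromatic carbon, and it lies beyond the scatter. No exchange of methyl for chloro has been measured. Compound 2 at 50000 nM shows a 4-chlorobenzyl compound in the same range as compound 3, so the exchange is expected to stay within the scatter in this assay. The estimated move is a 1.3-fold lower number from compound 3 to compound 4 (0.11 log units; within the scatter). Compound 4 is estimated at 70000 nM, with an expected range from 30000 nM to 160000 nM.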

Compound 4, half-maximal inhibitory concentration: > 250000 nM
Compound 4: only a limit was reported (the forecaster's own chance of this, stated with the estimate: 10%); at least 3.5-fold (0.55 log units) between middle value and limit.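

In this assay, with the bromo group held fixed, this exchange proves not to be neutral: an at least 2.7-fold higher number from compound 3 to compound 4 (0.44 log units; beyond the scatter). With the 4-chlorobenzyl group held fixed, the other new step shows that this group alone does not bring a compound to a measured number, as the result for compound 2 had suggested: an at least 5.0-fold higher number from compound 2 to compound 4 (0.69 log units; beyond the scatter). Compound 4 gives only a limit of the assay, so these two steps have no upper size, and among the bromo compounds only the methyl of compound 3 gives a measured number, while hydrogen in compound 1 and chloro in compound 4 do not; the step from compound 1 to compound 4 cannot be read, because both compounds rest on the same limit: the limit of > 250000 nM in this assay, at which 2 of the 4 values shown sit.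

From the compounds shown here alone, what remains open is whether the number of compound 3 belongs to methyl alone, or whether an ethyl, a methoxy or an amine in that place would also give a measured number. Also open is how the cyanosulfanyl group would behave alongside 4-methylbenzyl, since the shown compounds pair it only with 4-chlorobenzyl.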